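The source may hold more compounds than are shown below. What is called first, only, known or untested is meant among the compounds shown, and "the series" means these compounds.

Measured compounds:
- compound 1, `COc1cc(C(=O)/C=C/c2cn(-c3ccccc3)nc2-c2ccsc2)cc(OC)c1OC`: 3600 nM
- compound 2, `COc1ccc(C(=O)/C=C/c2cn(-c3ccccc3)nc2-c2ccsc2)cc1OC`: 2900 nM
- compound 3, `O=C(/C=C/c1cn(-c2ccccc2)nc1-c1cccnc1)c1ccccn1`: 6400 nM

In a functional assay on Huh-7 cells (Homo sapiens) for inhibition, read by sulforhodamine B assay, with a stated time of 72 h (on this read-out lower numbers stand for stronger inhibition and higher numbers for weaker inhibition), compound 1 stands second highest of the three numbers. For the measured compounds named here, its nearest neighbour is compound 2, and the one measured step, a 1.2-fold lower number from compound 1 to compound 2 (0.09 log units; within the scatter), lies within the scatter. Going by the values given here, compound 3 carries pyridin-3-yl on the core but also a different ketone aryl; it differs from compound 1 in two places, so no single step is recorded between them, and its value is within the scatter of compound 1.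

Compound 4, `COc1cc(C(=O)/C=C/c2cn(-c3ccccc3)nc2-c2cccnc2)cc(OC)c1OC`, is not yet measured. It differs from compound 1 only as follows: pyridin-3-yl in place of thiophen-3-yl on an aromatic carbon. Among the compounds with values here, no measured step covers this exchange on its own. Within the data shown here, the only compound with pyridin-3-yl on the core, compound 3, gives a number within the scatter of compound 1, so nothing in the data points to a step beyond the scatter in this assay in either direction.

For compound 4 the expected value in this assay is 4500 nM, with a range of 2000 nM to 10000 nM. The estimated step of a 1.3-fold higher number from compound 1 to compound 4 (0.10 log units; within the scatter) is therefore expected to stay within the scatter.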

Compound 4, half-maximal inhibitory concentration: 1900 nM
The estimate for compound 4 lay 2.4-fold (0.37 log units) above the measured number; the measured number lies below the stated range.
By their numbers in this assay, from the lowest: compounds 4, 2, 1 and 3 (each within the scatter of the next, the first and the last beyond it).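

In this assay the exchange on the shared core now has its own reading: a 1.9-fold lower number from compound 1 to compound 4 (0.28 log units; within the scatter), a step that stays within the scatter. With the rest of compound 1 held fixed, this aromatic carbon of the five-membered ring takes a six-membered aromatic ring with 1 hetero atom in place of a five-membered one, and the two compounds cannot be told apart in this assay. No measurement of any other property bears on this result, and the data give no reason for it.

The compounds shown hold only thiophen-3-yl and pyridin-3-yl at this position, so the reading for pyridin-4-yl, plain phenyl, an amine or a carboxylic acid there stays open. Also open, as far as these compounds go, is whether the exchange reads the same with a different ketone aryl.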